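A pyridyl amide among weak adenosine receptor ligands

A few compounds are considered here, and "the series" means these few. Any claim that something is new, unique, unknown or untested is made for them only; others in the source may bear on it.

Compound 1 `CCNC(=O)[C@H]1O[C@@H](n2cnc3c(NNC(=O)c4ccccc4)ncnc32)[C@H](O)[C@@H]1O`: > 5000 nM
Compound 2 `CCNC(=O)[C@H]1O[C@@H](n2cnc3c(NNC(=O)c4ccc(Cl)cc4)ncnc32)[C@H](O)[C@@H]1O`: > 5000 nM

In an assay on CHO cells for displacement of a labelled ligand from adenosine receptor A3 (Homo sapiens) (a lower number here means a stronger inhibitor, a higher number a weaker inhibitor), compound 1 is known only by a limit, giving > 5000 nM. Compound 2 is likewise known only by a limit, giving > 5000 nM. The step that the two limits leave unreadable from compound 1 to compound 2 therefore cannot be read, since both values sit at the limit of > 5000 nM in this assay, at which 2 of the 2 values shown sit. Compound 3 `CCNC(=O)[C@H]1O[C@@H](n2cnc3c(NNC(=O)c4cccnc4)ncnc32)[C@H](O)[C@@H]1O` differs from compound 2 by pyridin-3-yl in place of 4-chlorophenyl on a carbonyl carbon, so that the ring bearing the carbonyl becomes pyridin-3-yl. Among the compounds with values here, no measured step bears directly on this change, and compound 2 itself stands only at a limit, with no number to move from. The expectation for compound 3 rests solely on compound 2 standing at > 5000 nM and is that it again shows weak binding. Compound 3 is estimated at 8000 nM, within 2000 nM to 30000 nM. The step that the limit leaves unreadable from compound 2 to compound 3 is expected to stay within the scatter.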

Compound 3, inhibition constant: > 5000 nM
Compound 3: only a limit was reported (the forecaster's own chance of this, stated with the estimate: 80%); the middle value is on the limit's open side.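

In this assay compound 3 gives > 5000 nM as a limit. No step among compound 1, compound 2 and compound 3 can therefore be read, for all three stand at the same limit: the limit of > 5000 nM in this assay, at which 3 of the 3 values shown sit.

The compounds shown leave open which group on the carbonyl carbon, if any, would give a binding value that can be read as a number.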